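A Second Chloro Joins the Core of Compound 1

The source may hold more compounds than are shown below. What is called first, only, known or untested is meant among the compounds shown, and "the series" means these compounds.

Compound 1 `O=C1c2ccccc2N(Cc2ccccc2)S(=O)(=O)N1Cc1ccc(Cl)cc1`: 121000 nM
Compound 2 `O=C1c2ccccc2N(Cc2ccccc2)S(=O)(=O)N1Cc1ccccc1`: > 200000 nM
Compound 3 `O=C1c2ccccc2N(Cc2ccccc2)S(=O)(=O)N1COCc1ccccc1`: > 98000 nM

All three share one core and were tested in a functional assay on HEL cells (Homo sapiens) for inhibition; a lower number here means that less compound is tolerated, a higher number that more compound is tolerated. Among the compounds with values here, compound 1 gives 121000 nM, the only plain number among the three results. For compound 2 the assay reports only a limit, > 200000 nM. For compound 3 the result is again a limit, > 98000 nM. Because the limit of > 200000 nM in this assay, at which 1 of the 3 values shown sits, and the limit of > 98000 nM in this assay, at which 1 of the 3 values shown sits, cap two of the three results, the steps a step that the limit leaves unreadable from compound 1 to compound 3 and a step that the two limits leave unreadable from compound 2 to compound 3 cannot be sized. Within the data shown here, the one readable step is an at least 1.6-fold higher number from compound 1 to compound 2 (0.21 log units; that floor lies within the scatter), and its floor sits within the usual scatter.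

Compound 4 `O=C1c2ccccc2N(Cc2ccc(Cl)cc2)S(=O)(=O)N1Cc1ccc(Cl)cc1` has not yet been measured. It differs from compound 1 by chloro in place of hydrogen on an aromatic carbon; read one bond further out, a benzyl becomes a 4-chlorobenzyl. Among the measured compounds shown here, the only measured step that bears on this is the removal of a chloro in an at least 1.6-fold higher number from compound 1 to compound 2 (0.21 log units; that floor lies within the scatter), where the number rose a little at most. Adding a chloro to compound 1 is therefore expected to move the number slightly the other way, if at all, with the expected step being a 1.5-fold lower number from compound 1 to compound 4 (0.18 log units; within the scatter). Compound 4 is estimated at 80000 nM, within a range of 30000 nM to 200000 nM.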

Compound 4, half-maximal cytotoxic concentration: > 200000 nM
Compound 4 ended at the assay's limit; the forecaster's own chance of this, stated with the estimate: 20%; at least 2.5-fold (0.39 log units) between middle value and limit.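

In this assay compound 4 gives only a limit, > 200000 nM. Turning the benzyl into a 4-chlorobenzyl gives an at least 1.6-fold higher number from compound 1 to compound 4 (0.21 log units; that floor lies within the scatter), so this position shows no sign that a chloro on its aromatic ring lowers the number, which would have meant that less compound is tolerated; the printed floor alone cannot separate this step from no change at all. The real size of the step stays hidden, because the result of compound 4 is capped by a limit: the limit of > 200000 nM in this assay, at which 2 of the 4 values shown sit.

With compound 1 as the only plain number, the compounds shown say little about what, if anything, on this benzyl could bring the number down into a measurable range. An amine or a carboxylic acid in place of this chloro, or a longer chain between the core and the aromatic ring, remains an open question, and such a change would be readable only if its result fell clear of the limit.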